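The compounds below may be only part of what the source reports. "The series", "measured", "known", "first", "only" and "open" are said of these compounds alone.

Compounds measured so far:
compound 1, `COc1ccc([C@@H]2CC(=O)c3c(O)cc(OCc4cn(Cc5cccc(C(F)(F)F)c5)nn4)cc3O2)cc1O`, 19900 nM
compound 2, `COc1ccc([C@@H]2CC(=O)c3c(O)cc(OCc4cn(CC5CC5)nn4)cc3O2)cc1O`, 11900 nM

In a functional assay on RAW264.7 cells (Mus musculus) for inhibition, read by Griess assay, with stated times of 2 h and 24 h (a higher number here means a weaker inhibitor, a lower number a stronger inhibitor), compound 2 gives the lowest of the two numbers shown, though its neighbour compound 1 sits within the scatter of it: the step of a 1.7-fold lower number from compound 1 to compound 2 (0.22 log units; within the scatter) is small. Compound 3, `COc1ccc([C@@H]2CC(=O)c3c(O)cc(OCc4cn(Cc5ccccc5C)nn4)cc3O2)cc1O`, has not been measured. It differs from compound 2 in one place: 2-methylphenyl in place of cyclopropyl on a saturated chain carbon bound to an aromatic nitrogen. Within the data shown here, the one measured step that bears on this change is the one from compound 1 to compound 2, where a 3-(trifluoromethyl)phenyl gave way to cyclopropyl on the same saturated chain carbon bound to an aromatic nitrogen, and that step stayed within the scatter. Compound 3 brings back a six-membered aromatic ring at that position, so the account expects at most a modest move toward the number of compound 1, a 1.3-fold higher number from compound 2 to compound 3 (0.13 log units; within the scatter). Compound 3 is therefore estimated at 16000 nM, within the range 7000 nM to 36000 nM in this assay.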

Compound 3, half-maximal inhibitory concentration: 13100 nM
Compound 3: the middle estimate sits 1.2-fold (0.09 log units) above what was measured; the measured number falls inside the stated range.
By their numbers in this assay, from the lowest: compounds 2, 3 and 1 (each within the scatter of the next).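

In this assay, placing 2-methylphenyl on the saturated chain carbon bound to an aromatic nitrogen gives a 1.1-fold higher number from compound 2 to compound 3 (0.04 log units; within the scatter) against cyclopropyl and a 1.5-fold lower number from compound 1 to compound 3 (0.18 log units; within the scatter) against 3-(trifluoromethyl)phenyl, so both new steps stay within the scatter. The earlier pair offered a single comparison at this position, whereas three groups can now be compared, and cyclopropyl, 2-methylphenyl and 3-(trifluoromethyl)phenyl cannot be told apart by this read-out, whether or not the group carries an aromatic ring. There is no evidence here that accounts for this similarity. The compounds shown leave open whether any group at this position can move the number beyond the scatter, such as an amine, a carboxylic acid or a longer chain. They also leave open whether changes elsewhere on the shared core would do so.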